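Replacing tert-butyl with phenoxy on the aromatic ring

The compounds below may be only part of what the source reports. "The series", "measured", "known", "first", "only" and "open" are said of these compounds alone.

In a functional assay on PC-3 cells (Homo sapiens) for cytotoxicity, read by MTT assay, with a stated time of 48 h (a lower number here means a stronger inhibitor, a higher number a weaker inhibitor), compound 1 `CC1(C)CCC[C@]2(C)[C@@H](CC[C@@](C)(O)/C=C/c3cccc([N+](=O)[O-])c3)[C@](C)(O)CC[C@@H]12` gives 153 nM, while compound 2 `CC(C)(C)c1ccc(/C=C/[C@](C)(O)CC[C@@H]2[C@@]3(C)CCCC(C)(C)[C@@H]3CC[C@@]2(C)O)cc1` gives 3800 nM, the higher of the two numbers. Among the compounds with values here, the one measured step shows a 25-fold higher number from compound 1 to compound 2 (1.40 log units; beyond the scatter) as 4-(tert-butyl)phenyl replaces 3-nitrophenyl. Compound 3 `CC1(C)CCC[C@]2(C)[C@@H](CC[C@@](C)(O)/C=C/c3ccc(Oc4ccccc4)cc3)[C@](C)(O)CC[C@@H]12` shares the core of compound 2 and differs in one group: phenoxy in place of tert-butyl on an aromatic carbon. The measured step concerns a different replacement, so it is only a loose guide to size. In this assay, within the data shown here, the estimated change is small, a 1.5-fold lower number from compound 2 to compound 3 (0.18 log units; within the scatter), with no step expected beyond the scatter. For compound 3 the estimate is 2500 nM, with an expected range of 500 nM to 10000 nM.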

Compound 3, half-maximal inhibitory concentration: 268 nM
Estimate against measurement, compound 3: 9.3-fold (0.97 log units) above; the measured number lies below the stated range.
By their numbers in this assay, from the lowest: compounds 1 and 3 (each within the scatter of the next); then compound 2.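

In this assay, the group at this aromatic carbon proves decisive: phenoxy in place of tert-butyl brings a 14-fold lower number from compound 2 to compound 3 (1.15 log units; beyond the scatter) and so reverses much of the loss seen with the tert-butyl group. The high number of compound 2 therefore belongs to tert-butyl and not to every large group at this place. Compound 3 gives 268 nM and compound 1 gives 153 nM as values within the scatter of each other. From the compounds shown here alone, whether an amine or a carboxylic acid at this carbon would keep the number this low remains open. Nothing measured here accounts for the size of the step.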